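The source may report more compounds than this note shows. Statements on the series, on what has been measured and on what is new or still open speak of the compounds shown alone.

Measured compounds:
compound 1 `CCCCCCCCCCCCNC(=O)[C@@H](NC(=O)c1cc2ccccc2o1)[C@@H](C)O` — 20000 nM
compound 2 `CCCCCCCCCCCCNC(=O)[C@@H](NC(=O)c1nccc2ccccc12)[C@@H](C)O` — 62800 nM
compound 3 `CCCCCCCCCCCCCCNC(=O)[C@@H](NC(=O)c1cc2ccccc2o1)[C@@H](C)O` — 20100 nM

The three compounds were tested in a functional assay on A-431 cells (Homo sapiens) for cytotoxicity, read by MTT assay, with a stated time of 48 h; on this read-out lower numbers stand for stronger inhibition and higher numbers for weaker inhibition. Compound 1 and compound 2 share a core and differ in one place: isoquinolin-1-yl in place of 1-benzofuran-2-yl on a carbonyl carbon. That change gave a 3.1-fold higher number from compound 1 to compound 2 (0.50 log units; beyond the scatter). Compound 3 differs from compound 1 in the chain: ethyl in place of hydrogen on a saturated chain carbon, ten or more bonds along the chain from an amide-type nitrogen. That change gave a 1.0-fold higher number from compound 1 to compound 3 (0.00 log units; within the scatter).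

Compound 4 `CCCCCCCCCCCCCCNC(=O)[C@@H](NC(=O)c1nccc2ccccc12)[C@@H](C)O` has not yet been measured in this assay. It differs from compound 3 in the same way that compound 2 differs from compound 1: isoquinolin-1-yl in place of 1-benzofuran-2-yl on a carbonyl carbon. The place of the change is the same in both pairs, a carbonyl carbon whose other neighbour is an amide-type nitrogen, so this is the same change, made on the longer-chain core of compound 3.

Going by the values given here, the expectation for compound 4 rests on two things: the step of a 3.1-fold higher number from compound 1 to compound 2 (0.50 log units; beyond the scatter), which is the only prior example of this change, and the step of a 1.0-fold higher number from compound 1 to compound 3 (0.00 log units; within the scatter), which suggests the longer chain alone changes little. Compound 4 is therefore expected to show roughly a 3.1-fold higher number from compound 3 to compound 4 (0.49 log units; beyond the scatter), a step of similar size to the earlier one. Compound 4 is estimated at 62000 nM, with a likely range from 30000 nM to 130000 nM.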

Compound 4, half-maximal inhibitory concentration: 23000 nM
For compound 4 the middle estimate is 2.7-fold (0.43 log units) above the measured one; the whole stated range lies above it.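

In this assay, putting isoquinolin-1-yl in place of 1-benzofuran-2-yl on the longer-chain core gave a 1.1-fold higher number from compound 3 to compound 4 (0.06 log units; within the scatter), so the change did not carry over at the size seen on the shorter-chain core: the same change on two cores in this assay, a 3.1-fold higher number (0.50 log units; beyond the scatter) from compound 1 to compound 2 and a 1.1-fold higher number (0.06 log units; within the scatter) from compound 3 to compound 4, 2.7-fold (0.44 log units) apart, beyond the scatter of two such steps. Read the other way, the longer chain gave a 2.7-fold lower number from compound 2 to compound 4 (0.44 log units; beyond the scatter) when isoquinolin-1-yl was present, whereas with 1-benzofuran-2-yl its step stayed within the scatter: the same change on two cores in this assay, a 1.0-fold higher number (0.00 log units; within the scatter) from compound 1 to compound 3 and a 2.7-fold lower number (0.44 log units; beyond the scatter) from compound 2 to compound 4, 2.7-fold (0.44 log units) apart, beyond the scatter of two such steps. The four compounds therefore show that, in this cytotoxicity read-out, the effects of the two changes do not simply add, but they do not show why, and a single pair of cores gives no rule for carrying the change to any other core.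

Going by these compounds, it remains open whether the effect of the aromatic group would depend in the same way on a shorter chain or a still longer chain. On these data alone, it is also open how a phenyl group on the carbonyl carbon would behave on these two cores.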